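Replacing the Piperidinyl Amide with Chloro on the Coumarin

A few compounds are considered here, and "the series" means these few. Any claim that something is new, unique, unknown or untested is made for them only; others in the source may bear on it.

Among the measured compounds, compound 3 `O=C(COc1cc(=O)oc2cc(OCc3cccc(Cl)c3)ccc12)N1CCCCC1` gives the highest number in an assay on isolated protein (strain Sprague-Dawley) for inhibition of Amine oxidase [flavin-containing] B (Rattus norvegicus), read by spectrophotometry, with a stated time of 5 min (a higher number here means a weaker inhibitor, a lower number a stronger inhibitor), namely 38900 nM. Compound 1 `CC(=O)COc1cc(=O)oc2cc(OCc3cccc(Cl)c3)ccc12` gives 26.9 nM, and compound 2 `CNC(=O)COc1cc(=O)oc2cc(OCc3cccc(Cl)c3)ccc12` gives 33.9 nM; the step of a 1.3-fold higher number from compound 1 to compound 2 (0.10 log units; within the scatter) lies within the scatter, whereas a 1400-fold higher number from compound 1 to compound 3 (3.16 log units; beyond the scatter) and a 1100-fold higher number from compound 2 to compound 3 (3.06 log units; beyond the scatter) are large. Compound 4 `O=c1cc(Cl)c2ccc(OCc3cccc(Cl)c3)cc2o1` arises by chloro in place of ((piperidin-1-yl)carbonyl)methoxy on an aromatic carbon. Going by the values given here, no measured step matches this exchange; the two large steps show only that the group now leaving goes with a much higher number. The estimate for compound 4 therefore expects a large step downward, a 650-fold lower number from compound 3 to compound 4 (2.81 log units; beyond the scatter), towards compounds 1 and 2. Compound 4 is expected to give 60 nM, within a range of 6 nM to 600 nM.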

Compound 4, half-maximal inhibitory concentration: 20.9 nM
Beside the measured number, compound 4's estimate is 2.9-fold (0.46 log units) above it; measured number inside the range.
By their numbers in this assay, from the lowest: compounds 4, 1 and 2 (each within the scatter of the next); then compound 3.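

In this assay, going by these compounds alone, this place on the shared core does not require an ether side chain: the single chloro of compound 4 stands level with the two small side chains (a 1.3-fold lower number from compound 1 to compound 4 (0.11 log units; within the scatter); a 1.6-fold lower number from compound 2 to compound 4 (0.21 log units; within the scatter)). The large step (a 1900-fold lower number from compound 3 to compound 4 (3.27 log units; beyond the scatter)) ties the high number of compound 3 to ((piperidin-1-yl)carbonyl)methoxy rather than to the place itself. No evidence is available to explain these numbers.

On these data alone, it remains open whether bromo, methoxy or an amine at this place would match chloro. As far as these compounds go, it also remains open whether a morpholine amide would share the high number of the piperidine amide.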